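Phenylethynyl salicylate series: removing the phenolic hydroxy

The source may report more compounds than this note shows. Statements on the series, on what has been measured and on what is new or still open speak of the compounds shown alone.

Measured so far:
compound 1 `O=C(O)c1cc(CCc2ccc(S(=O)(=O)Nc3ccccn3)cc2)ccc1O`, 700000 nM
compound 2 `O=C(O)c1cc(/N=N/c2ccccc2)ccc1O`, 200000 nM
compound 3 `O=C(O)c1cc(C#Cc2ccccc2)ccc1O`, 150000 nM

In an assay on U-87MG ATCC cells for inhibition of cystine/glutamate transporter (Homo sapiens), read by scintillation counting, with a stated time of 15 min (a lower number here means a stronger inhibitor, a higher number a weaker inhibitor), compound 3 gives the lowest of the three numbers. Its nearest neighbour is compound 2, which lies within the scatter of it; compound 1 sits beyond the scatter, weaker. Among the compounds with values here, all three share the salicylate fragment, so no measured pair tells what the hydroxy contributes.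

Compound 4 `O=C(O)c1cccc(C#Cc2ccccc2)c1` differs from compound 3 by hydrogen in place of hydroxy on an aromatic carbon. Without a measured step for this change, a moderate weakening is expected, beyond the scatter but not large: the step from compound 3 to compound 4 in this assay is estimated as a 3.3-fold higher number from compound 3 to compound 4 (0.52 log units; beyond the scatter). Compound 4 is expected to give about 500000 nM, within 150000 nM to 2000000 nM.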

Compound 4, half-maximal inhibitory concentration: 270000 nM
Compound 4: the middle estimate sits 1.9-fold (0.27 log units) above what was measured; measured number inside the range.
By their numbers in this assay, from the lowest: compounds 3, 2 and 4 (each within the scatter of the next); then compound 1.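

In this assay, hydrogen in place of hydroxy, ortho to a carboxy group, gives a 1.8-fold higher number from compound 3 to compound 4 (0.26 log units; within the scatter). Within the data shown here, this is the first measured pair at this position, and on this core the change does not move the number beyond the scatter, so the hydroxy shows no measurable contribution here. No supporting data are available to explain this result.

Going by these compounds, a methoxy or an amine at this position remains open. So does whether the same change would behave alike on the cores of compound 1 and compound 2.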